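A few compounds are considered here, and "the series" means these few. Any claim that something is new, unique, unknown or untested is made for them only; others in the source may bear on it.

Series notes. Compound 1 `CC(C)C(Cc1nnn[nH]1)c1ccc(-c2ccc3cccc(F)c3c2)[nH]c1=O` gives 134 nM in a functional assay on CHO cells for antagonist activity at prostaglandin E2 receptor EP3 subtype (Homo sapiens), read by cAMP accumulation; a higher number here means a weaker inhibitor, a lower number a stronger inhibitor. Compound 2 `CC(C)C(c1noc(=O)[nH]1)c1ccc(-c2ccc3cccc(F)c3c2)[nH]c1=O` gives 41 nM in this assay, and compound 3 `CC(C)C(CC(N)=O)c1ccc(-c2ccc3cccc(F)c3c2)[nH]c1=O` gives 53 nM in this assay. Compound 3 thus stands second highest of the three numbers; its nearest neighbour is compound 2, with a 1.3-fold higher number from compound 2 to compound 3 (0.11 log units; within the scatter), and its furthest is compound 1, with a 2.5-fold lower number from compound 1 to compound 3 (0.40 log units; beyond the scatter). The remaining measured step, a 3.3-fold lower number from compound 1 to compound 2 (0.51 log units; beyond the scatter), is the largest of the three and does not touch compound 3.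

Compound 4 `CC(C)NC(=O)CC(c1ccc(-c2ccc3cccc(F)c3c2)[nH]c1=O)C(C)C` differs from compound 3 by isopropyl in place of hydrogen on an amide-type nitrogen. None of the three measured steps alters an amide-type nitrogen; each exchanges the whole group on the saturated chain carbon bound to the aromatic carbon. They therefore give no direct guide to the size or direction of the change in this assay for compound 4, and the working assumption is a step that does not clearly exceed the scatter, with wide uncertainty either way. For compound 4 the expected step is a 1.3-fold higher number from compound 3 to compound 4 (0.12 log units; within the scatter). Compound 4 is estimated at 70 nM in this assay, within 20 nM to 250 nM.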

Compound 4, half-maximal inhibitory concentration in the prostaglandin E2 receptor EP3 subtype assay: 15 nM
Beside the measured number, compound 4's estimate is 4.7-fold (0.67 log units) above it, outside the stated range (below it).
By their numbers in the prostaglandin E2 receptor EP3 subtype assay, from the lowest: compound 4; then compounds 2 and 3 (each within the scatter of the next); then compound 1.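

For the compounds shown here, in the prostaglandin E2 receptor EP3 subtype assay isopropyl in place of hydrogen on an amide-type nitrogen gives a 3.5-fold lower number from compound 3 to compound 4 (0.55 log units; beyond the scatter) and so shows that this nitrogen, untouched by the earlier steps, is a place where the number can fall. The isopropylcarbamoyl group also improves on both ring-bearing groups, with a 2.7-fold lower number from compound 2 to compound 4 (0.44 log units; beyond the scatter) and an 8.9-fold lower number from compound 1 to compound 4 (0.95 log units; beyond the scatter) as the two readings, whereas a 1.3-fold higher number from compound 2 to compound 3 (0.11 log units; within the scatter) left the plain carbamoyl level with the five-membered ring. In a physicochemical assay for solubility, in phosphate buffer, measured as kinetic solubility (a lower number here means a less soluble compound, a higher number a more soluble compound), compound 3 gives 5600 nM and compound 4 gives 18000 nM. In the physicochemical assay the same change goes with a more soluble compound, not a less soluble one: the measured solubility of compound 3, 5600 nM, and of compound 4, 18000 nM, a 3.2-fold higher number (0.51 log units; beyond the scatter).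

On these data alone, only one substituent on this nitrogen appears, so it stays open whether methyl, tert-butyl or a hydroxyethyl chain would move the number the same way. As far as these compounds go, how a carboxylic acid in place of the amide would compare also remains open.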